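The compounds below may be only part of what the source reports. "The series", "measured", "known", "first", "only" and "open" are said of these compounds alone.

Among the compounds with values here, compound 2 `Fc1ccccc1Cn1cc(CSC(=S)N2CCNCC2)nn1` gives 56200 nM in a functional assay on PC-3 cells (Homo sapiens) for inhibition, read by MTT assay, with a stated time of 72 h (on this read-out lower numbers stand for stronger inhibition and higher numbers for weaker inhibition), and holds the lowest of the two numbers read so far. Within the data shown here, compound 1 `O=C(OCc1ccccc1)N1CCN(C(=S)SCc2cn(Cc3ccccc3F)nn2)CC1` gives 68300 nM in this assay, and the step of a 1.2-fold lower number from compound 1 to compound 2 (0.08 log units; within the scatter) is the only single-point step in hand. Compound 3 `CC(C)(C)OC(=O)N1CCN(C(=S)SCc2cn(CCOc3ccc4ccc(=O)oc4c3)nn2)CC1` returns only a limit, > 128000 nM, in this assay. Compound 4 `COc1ccc(Cn2cc(CSC(=S)N3CCNCC3)nn2)cc1` is the next to be measured; it differs from compound 2 by 4-methoxyphenyl in place of 2-fluorophenyl on a saturated chain carbon bound to an aromatic nitrogen. Among the measured compounds shown here, no measured step touches that place: the one step available changes the amine nitrogen in the ring and was within the scatter, and nothing in hand speaks to the aryl group. The step expected for compound 4 is a 1.0-fold lower number from compound 2 to compound 4 (0.00 log units; within the scatter), none beyond the scatter. The estimate for compound 4 is 56000 nM, with a range from 20000 nM to 150000 nM.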

Compound 4, half-maximal inhibitory concentration: > 128000 nM
Compound 4: a limit, no number; the forecaster's own chance of this, stated with the estimate: 25%; at least 2.2-fold (0.35 log units) between middle value and limit.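

In this assay, within the data shown here, the aryl group on a saturated chain carbon bound to an aromatic nitrogen gives the first change beyond the scatter: an at least 2.2-fold higher number from compound 2 to compound 4 (0.35 log units; beyond the scatter), with 4-methoxyphenyl in place of 2-fluorophenyl. The earlier step on the amine nitrogen in the ring stayed within the scatter, so this is the only place shown to respond. The value for compound 4 is a limit, not a number: the limit of > 128000 nM in this assay, at which 2 of the 4 values shown sit.

Among these compounds, the single change swaps both the fluorine and the methoxy group, and these compounds do not separate the two. From the compounds shown here alone, how a plain phenyl group or an amine-bearing aryl group would read at this place remains open.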